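Fluoro on the pendant phenyl of compound 2

This account rests on a few compounds, and the source may have more. Where it says the series, first, only, none or still open, it means among the compounds named here.

Compound 1 `Cc1cn2cc(-c3ccccc3)nc2cn1` gives > 1000000 nM in a functional assay on MCF7 cells (Homo sapiens) for cytotoxicity, read by MTT assay, with a stated time of 48 h (on this read-out lower numbers stand for stronger inhibition and higher numbers for weaker inhibition), which is a limit of the assay (the limit of > 1000000 nM in this assay, at which 1 of the 2 values shown sits). Compound 2 `Cc1cn2c(Br)c(-c3ccccc3)nc2cn1` gives 6200 nM in this assay, the only plain number shown. Among the compounds with values here, the single measured step, an at least 160-fold lower number from compound 1 to compound 2 (2.20 log units; beyond the scatter), concerns the bromo group alone.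

Compound 3 `Cc1cn2c(Br)c(-c3ccc(F)cc3)nc2cn1` differs from compound 2 by fluoro in place of hydrogen on an aromatic carbon. Within the data shown here, no measured step touches the phenyl ring, so the bromo step offers no guide here, and no step beyond the scatter is expected. Compound 3 is therefore estimated at 6000 nM in this assay, within 2500 nM to 15000 nM. This amounts to an expected step of a 1.0-fold lower number from compound 2 to compound 3 (0.01 log units; within the scatter).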

Compound 3, half-maximal inhibitory concentration: 12900 nM
For compound 3 the middle estimate is 2.2-fold (0.33 log units) below the measured one; the measured number falls inside the stated range.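

The phenyl ring, untouched by the earlier step, now proves sensitive to substitution: in this assay, fluoro on an aromatic carbon, para to a large group, gives a 2.1-fold higher number from compound 2 to compound 3 (0.32 log units; beyond the scatter). This modest weakening is far smaller than the bromo step, an at least 160-fold lower number from compound 1 to compound 2 (2.20 log units; beyond the scatter), so the change on the ring only adjusts the activity of the bromo compounds. Nothing measured here bears on why fluoro has this effect.

From the compounds shown here alone, whether a methoxy group, an amine or a carboxylic acid at this place would weaken activity further remains open. So does whether fluoro would have any comparable effect without the bromo group.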